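Sulfonamide series: quinoxalinyl for pyridinyl on the compound 1 core

The compounds below may be only part of what the source reports. "The series", "measured", "known", "first", "only" and "open" are said of these compounds alone.

Three compounds of this series carry a measurement in a functional assay on MCF7 cells (Homo sapiens) for antiproliferative activity, read by sulforhodamine B assay, with a stated time of 48 h; a higher number here means a weaker inhibitor, a lower number a stronger inhibitor. Compound 1 `NC1=NN(c2ccccc2)C(=O)/C1=C/Nc1ccc(S(=O)(=O)Nc2ccccn2)cc1` gives 5100 nM. Compound 2 `Cc1cc(C)nc(NS(=O)(=O)c2ccc(N/C=C3/C(=N)N(c4ccccc4)N=C3N)cc2)n1` gives 6980 nM, and compound 3 `N=C1NN=C(N)/C1=C\Nc1ccc(S(=O)(=O)Nc2cnc3ccccc3n2)cc1` gives 7780 nM. The three numbers sit within the usual scatter of one another, so compound 1 is not separated from compound 2 or compound 3 by anything that the assay can resolve; it is simply the point from which the next step is taken.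

Compound 4 `NC1=NN(c2ccccc2)C(=O)/C1=C/Nc1ccc(S(=O)(=O)Nc2cnc3ccccc3n2)cc1` is not yet measured. It differs from compound 1 in one place: quinoxalin-2-yl in place of pyridin-2-yl on a sulfonamide nitrogen. Among the measured compounds shown here, no pair of measured compounds differs in exactly this way, so there is no measured step of the same kind to lean on. Compound 3 carries the quinoxalin-2-yl group but on a different shared core, so its value of 7780 nM can only be read as showing that this group is compatible with numbers in the same range as compound 1.

On that basis the step from compound 1 to compound 4 is expected to be a 1.1-fold higher number from compound 1 to compound 4 (0.03 log units; within the scatter), that is, no change beyond the scatter in either direction. Compound 4 is therefore estimated at 5500 nM, with a range from 2500 nM to 12000 nM.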

Compound 4, half-maximal inhibitory concentration: 6710 nM
Compound 4: the middle estimate sits 1.2-fold (0.09 log units) below what was measured, and the stated range covers the measured number.
By their numbers in this assay, from the lowest: compounds 1, 4, 2 and 3 (each within the scatter of the next).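

In this assay, placing quinoxalin-2-yl on the sulfonamide nitrogen in place of pyridin-2-yl gives a 1.3-fold higher number from compound 1 to compound 4 (0.12 log units; within the scatter). Among the compounds shown here, this is the first reading of a change at this position with the core of compound 1 held constant, and it extends what compound 3 could only suggest from a different core: quinoxalin-2-yl, with its added six-membered aromatic ring of carbon only and its second ring nitrogen, is tolerated here without a change that the assay can resolve. No measured evidence is available to explain why the number holds across this exchange.

The compounds shown leave open whether any group on this sulfonamide nitrogen can move the number beyond the scatter, since both aromatic groups compared on this core give values that the assay cannot separate. A small non-aromatic group such as methyl or acetyl, or an aromatic ring carrying an amine or a carboxylic acid, would test whether this position responds at all or whether the antiproliferative reading depends on other parts of the structure.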